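This account rests on a few compounds, and the source may have more. Where it says the series, first, only, none or still open, it means among the compounds named here.

Measured compounds:
Compound 1 `CC(C)C(=O)OCOC(=O)C1=C(S[C@@H]2CN[C@H](C(=O)Nc3cccc(C(=O)OCOC(=O)C(C)C)c3)C2)[C@H](C)[C@@H]2[C@@H]([C@@H](C)O)C(=O)N12`: 8%
Compound 2 `Cc1oc(=O)oc1COC(=O)N1C[C@@H]2C[C@H]1C(=O)Nc1cccc(c1)C(=O)OC/C=C/COC(=O)C1=C(S2)[C@H](C)[C@@H]2[C@@H]([C@@H](C)O)C(=O)N12`: 17%

In an ADME assay on a cell-free system (plasma, Homo sapiens) for metabolic stability, read by LC-MS, with a stated time of 60 min, at 37 degrees C, tested at 50 uM (a higher number here means that more of the compound is left, a lower number that less of the compound is left), compound 1 gives 8%, the lowest of the two numbers, and compound 2 gives 17%, a number that lies within the scatter of compound 1, so no order between the two can be claimed. For the measured compounds named here, no step between measured compounds that differ in one place is available, and the two measured structures differ in several places at once.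

Compound 3 `CC(C)C(=O)OCOC(=O)C1=C(S[C@@H]2CN[C@H](C(=O)Nc3cccc(C(=O)O)c3)C2)[C@H](C)[C@@H]2[C@@H]([C@@H](C)O)C(=O)N12` has not been measured in this assay . It differs from compound 1 in a single place: hydrogen in place of ((isopropylcarbonyl)oxy)methyl on an oxygen next to a carbonyl group. Going by the values given here, nothing among the measured compounds isolates this change, so its expected size rests on the values of compound 1 and compound 2 alone. The estimated step from compound 1 to compound 3 is a small rise, a number 7 percentage points higher from compound 1 to compound 3 (within the scatter), one that may not reach beyond the scatter. Compound 3 is therefore expected to give about 15% in this assay , with a range from 4% to 40%.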

Compound 3, percent of the compound remaining: 15%
The estimate for compound 3 equals the measured number at the digits printed, within the range that was stated.
By their numbers in this assay, from the lowest: compounds 1, 3 and 2 (each within the scatter of the next).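

In this assay, for the compounds shown here, this is the first comparison in which only one place differs: hydrogen stands in place of ((isopropylcarbonyl)oxy)methyl on an oxygen next to a carbonyl group, and the step is a number 7 percentage points higher from compound 1 to compound 3 (within the scatter). At this position, therefore, the exchange of that group for hydrogen, which leaves a free carboxylic acid, gives a number that cannot be told apart from that of compound 1, and the remaining ((isopropylcarbonyl)oxy)methyl shared by compound 1 and compound 3 is the same in both. Nothing at hand explains why the two numbers lie so close together, and no cause can be assigned to this single step.

The compounds shown leave open what a simple methyl or ethyl group on the same oxygen, or an amide in place of the carboxylic acid, would give in this assay. On these data alone, they also leave open what hydrogen in place of the remaining ((isopropylcarbonyl)oxy)methyl would give, alone or together with the carboxylic acid of compound 3, so the contribution of that second place remains unknown.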